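The source may report more compounds than this note shows. Statements on the series, on what has been measured and on what is new or still open speak of the compounds shown alone.

Compound 3 `CCOC(=O)c1[nH]c2cc(Cl)ccc2c1/C=N/NC(=O)CCC(C)C` shares its core with compound 1 `CCOC(=O)c1[nH]c2cc(Cl)ccc2c1/C=N/NC(=O)Cc1ccccc1` and compound 2 `CCOC(=O)c1[nH]c2cc(Cl)ccc2c1/C=N/NC(=O)Cc1cccs1`. In an assay for inhibition of Polyunsaturated fatty acid lipoxygenase ALOX15 (Homo sapiens), with a stated time of 8 min (a higher number here means a weaker inhibitor, a lower number a stronger inhibitor), compound 1 reaches only a limit of > 10000 nM. Compound 2 likewise gives only a limit, > 10000 nM. Compound 3 also stops at a limit of > 10000 nM. The three connecting steps, a step that the two limits leave unreadable from compound 1 to compound 2, a step that the two limits leave unreadable from compound 1 to compound 3 and a step that the two limits leave unreadable from compound 2 to compound 3, cannot be sized because of the limit of > 10000 nM in this assay, at which 3 of the 3 values shown sit. Compound 4 `CCOC(=O)c1[nH]c2cc(Cl)ccc2c1/C=N/NC(=O)CNc1cccc([N+](=O)[O-])c1` differs from compound 3 in (3-nitrophenyl)amino in place of isobutyl on a saturated chain carbon bound to a carbonyl carbon. Among the compounds with values here, no measured step bears on this change, and none of the measured steps has a readable size, so no direction can be drawn from them. Compound 4 is therefore expected to give about 20000 nM, within a range from 3000 nM to 100000 nM. The implied step that the limit leaves unreadable from compound 3 to compound 4 is expected to stay unreadable against a limit.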

Compound 4, half-maximal inhibitory concentration: > 10000 nM
Compound 4: no number, only a limit (the forecaster's own chance of this, stated with the estimate: 70%); the middle value lies beyond the limit too.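

No step joining compound 4 to compound 1, compound 2 or compound 3 can be read, because each pair rests on the same limit: the limit of > 10000 nM in this assay, at which 4 of the 4 values shown sit.

The compounds shown leave open whether any group on this saturated chain carbon would give a number rather than a limit in this assay.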